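Extending the Hydroxymethyl Side Chain of Compound 2

The source may report more compounds than this note shows. Statements on the series, on what has been measured and on what is new or still open speak of the compounds shown alone.

Of the compounds shown here, three sharing one core have been measured in an assay on isolated protein for inhibition of ubiquitin carboxyl-terminal hydrolase 47 (Homo sapiens); a higher number here means a weaker inhibitor, a lower number a stronger inhibitor. Compound 1 `Nc1cc(-c2cc(Cl)cc3c2OC(C(=O)N2CCNCC2)C3)ccn1` reaches only a limit there, giving > 80000 nM. Compound 3 `O=C(C1Cc2cc(Cl)cc(-c3ccnc4[nH]ccc34)c2O1)N1CCNCC1` likewise shows only a limit, > 80000 nM. The step that the two limits leave unreadable from compound 1 to compound 3 therefore has no readable size. Compound 2 `O=C([C@H]1Cc2cc(Cl)cc(-c3ccnc4cc(CO)sc34)c2O1)N1CCNCC1` also sits at a limit, with > 40000 nM. Compound 2 thus stands at the limit of > 40000 nM in this assay, at which 1 of the 3 values shown sits, whereas the limit of > 80000 nM in this assay, at which 2 of the 3 values shown sit, holds the other two. Compound 4 `O=C([C@H]1Cc2cc(Cl)cc(-c3ccnc4cc(C(O)(CO)CCl)sc34)c2O1)N1CCNCC1` differs from compound 2 by 1-(chloromethyl)-1,2-dihydroxyethyl in place of hydroxymethyl on an aromatic carbon. No measured step touches this site, and the single step shown is unreadable, so no change beyond the scatter can be anticipated in this assay. Compound 4 is expected to give about 40000 nM, within 20000 nM to 80000 nM, most likely again as a limit, an expected step of a number no higher from compound 2 to compound 4 (the limit leaves the size open).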

Compound 4, half-maximal inhibitory concentration: > 40000 nM
Compound 4: only a limit was reported; the forecaster's own chance of this, stated with the estimate: 85%; the middle value lies on the limit itself.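

In this assay compound 4 gives > 40000 nM, a limit, and compound 2 also stands at a limit, so the step between them cannot be read. The compounds shown leave open how strongly any of them inhibits, and whether 1-(chloromethyl)-1,2-dihydroxyethyl in place of hydroxymethyl changes that at all.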